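Chloro to Methyl: Estimating Compound 4 in Cell Assay

The source may report more compounds than this note shows. Statements on the series, on what has been measured and on what is new or still open speak of the compounds shown alone.

Of the compounds shown here, three built on one shared core have been tested in a functional assay on MDA-MB-231 cells (Homo sapiens) for inhibition, read by MTT assay, with a stated time of 72 h; on this read-out lower numbers stand for stronger inhibition and higher numbers for weaker inhibition. Compound 1 `O=[N+]([O-])c1ccccc1Nc1nnc(-c2c[nH]c3ccccc23)o1` gives 900 nM. Compound 2 `Clc1ccc(Nc2nnc(-c3c[nH]c4ccccc34)o2)cc1` gives 9770 nM, which stands as the second highest of the three numbers, with compound 3 nearest and compound 1 furthest from it. Compound 3 `Clc1ccc(Nc2nnc(-c3c[nH]c4ccccc34)o2)cc1Cl` gives 31100 nM. Among the measured compounds shown here, the one step between compounds that differ in a single place is a 3.2-fold higher number from compound 2 to compound 3 (0.50 log units; beyond the scatter), where chloro replaces hydrogen on an aromatic carbon. Compound 1 and compound 2 differ in more than one place, so their values only show a gap.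

Compound 4 `Cc1ccc(Nc2nnc(-c3c[nH]c4ccccc34)o2)cc1` has not yet been measured. It differs from compound 2 by methyl in place of chloro on an aromatic carbon. For the measured compounds named here, no measured step swaps chloro for methyl, so nothing here speaks directly to this change; the only step available, from compound 2 to compound 3, adds a second chloro and was modest. With no direct guidance, the change is expected to leave the number close to that of compound 2. The step it would mean, a 1.0-fold higher number from compound 2 to compound 4 (0.01 log units; within the scatter), is expected to stay within the usual scatter. Compound 4 is therefore expected to give 10000 nM, with a range from 3000 nM to 35000 nM.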

Compound 4, half-maximal inhibitory concentration: 27300 nM
Compound 4: middle estimate off by 2.7-fold (0.44 log units), on the low side; the range from low to high includes it.
By their numbers in this assay, from the lowest: compound 1; then compound 2; then compounds 4 and 3 (each within the scatter of the next).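

In this assay, replacing chloro with methyl on this aromatic carbon, para to a large group, gives a 2.8-fold higher number from compound 2 to compound 4 (0.45 log units; beyond the scatter) and so moves the read-out toward weaker inhibition, a modest change but one beyond the scatter. The earlier single-place step added a second chloro to the ring, whereas this one exchanges the group at this position itself and shows that the position is sensitive to the choice of group: chloro and methyl each have one heavy atom, no hydrogen-bond donors or acceptors and no net charge, yet the two compounds can be told apart in this assay. No measured property on hand accounts for the difference between these two groups.

The compounds shown leave open how other groups at this position would read, such as methoxy, an amine or a carboxylic acid, and whether a longer chain such as ethyl would move the number further from that of compound 2 or back toward it. This single pair also leaves open whether the same exchange would give a similar step with a second group on the ring or on a different core.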